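Swapping methoxy for fluoro on the shared core

This account rests on a few compounds, and the source may have more. Where it says the series, first, only, none or still open, it means among the compounds named here.

Of the compounds shown here, two with the same shared core have been tested so far. Compound 1 `CCOC(=O)[C@H](CCC(=O)O)NC(=O)c1ccc(Oc2nc3cc(N)cc(N)c3nc2-c2ccccc2)cc1` carries a much larger side chain; in a functional assay on MDA-MB-231 cells (Homo sapiens) for inhibition, read by sulforhodamine B assay, with a stated time of 48 h (a higher number here means that more compound is tolerated, a lower number that less compound is tolerated), compound 1 gives 93300 nM. Compound 2 `COc1ccc(Sc2nc3cc(N)cc(N)c3nc2-c2ccccc2)cc1` is simpler, and for it the result is only a limit of the assay: in this assay compound 2 gives < 100000 nM. This is the limit recorded as the limit of < 100000 nM in this assay, at which 1 of the 2 values shown sits, so compound 2 stands at the edge of what the assay reports rather than at a settled number. Compound 3 `Nc1cc(N)c2nc(-c3ccccc3)c(Sc3ccc(F)cc3)nc2c1` differs from compound 2 in one place: fluoro in place of methoxy on an aromatic carbon. Going by the values given here, no measured pair shows what such a swap does on this core, and the change is small. The step from compound 2 to compound 3 is therefore expected to be a step that the limit leaves unreadable from compound 2 to compound 3, that is, none beyond the usual scatter. In this assay compound 3 is estimated at 70000 nM, within a range from 20000 nM to 150000 nM.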

Compound 3, concentration lethal to 50% of the cells: 83200 nM
The estimate for compound 3 lay 1.2-fold (0.08 log units) below the measured number; the range from low to high includes it.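

No size can be read for the swap of methoxy for fluoro between compound 2 and compound 3, because the result for compound 2 is only a limit of the assay: the limit of < 100000 nM in this assay, at which 1 of the 3 values shown sits.

The compounds shown leave open how much this swap changes the tolerated concentration on the shared core.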